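A Chlorophenyl Partner for a Shared Core

A few compounds are considered here, and "the series" means these few. Any claim that something is new, unique, unknown or untested is made for them only; others in the source may bear on it.

Of the compounds shown here, three on a shared core have been tested in a functional assay on K562 cells (Homo sapiens) for antiproliferative activity, read by MTT assay, with a stated time of 24 h; on this read-out higher numbers stand for weaker inhibition and lower numbers for stronger inhibition. Compound 1 `COc1ccc(C(=O)/C=C/c2cc(OC)c(OC)c(OC)c2)c2c1C=CC(C)(C)O2` reaches only the limit of the assay, giving > 10000 nM. Compound 2 `COc1ccc(/C=C/C(=O)c2ccc(OC)c3c2OC(C)(C)C=C3)c(F)c1` likewise reaches only a limit, giving > 10000 nM in this assay. Compound 3 `COc1ccc(C(=O)/C=C/c2cccc3ccccc23)c2c1C=CC(C)(C)O2` also stops at a limit, giving > 10000 nM. Compound 2 therefore stands nowhere apart from the other two, since all of them sit at the limit of > 10000 nM in this assay, at which 3 of the 3 values shown sit. Going by the values given here, no step between two numbers can be drawn from these values.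

Compound 4 `COc1ccc(C(=O)/C=C/c2cccc(Cl)c2)c2c1C=CC(C)(C)O2` is not yet measured. It differs from compound 2 in one place: 3-chlorophenyl in place of 2-fluoro-4-methoxyphenyl on a double-bonded chain carbon bound to a double-bonded chain carbon. With every measured compound at a limit, the values give no direction to build on. The step that the limit leaves unreadable from compound 2 to compound 4 is expected to be none beyond the scatter, with compound 4 expected to remain at or near the limit. The estimate for compound 4 in this assay is 15000 nM, in a range from 5000 nM to 50000 nM.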

Compound 4, half-maximal inhibitory concentration: > 10000 nM
Compound 4: no number, only a limit (the forecaster's own chance of this, stated with the estimate: 80%); the middle value is on the limit's open side.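

Going by these compounds alone, compound 2 and compound 4 both stop at a limit, so no step between them can be read. The compounds shown leave open how 3-chlorophenyl compares with 2-fluoro-4-methoxyphenyl, and whether any compound on the shared core gives a number rather than a limit.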